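Methyl in place of methylamino: expected step for compound 3

The compounds below may be only part of what the source reports. "The series", "measured", "known", "first", "only" and "open" are said of these compounds alone.

Values in an ADME assay on MRC5 cells (Homo sapiens), read by MTT assay, with a stated time of 72 h (on this read-out lower numbers stand for stronger inhibition and higher numbers for weaker inhibition), so far:
- compound 1 `CNc1ncnc2c1c(-c1cccs1)cn2[C@@H]1O[C@H](CO)[C@@H](O)[C@H]1O` gives > 100000 nM as a limit
- compound 2 `CNc1ncnc2c1c(-c1cc3ccccc3o1)cn2[C@@H]1O[C@H](CO)[C@@H](O)[C@H]1O` gives 75300 nM

Compound 1 reads > 100000 nM in this assay and that is a limit, not a number. Compound 3 `Cc1ncnc2c1c(-c1cccs1)cn2[C@@H]1O[C@H](CO)[C@@H](O)[C@H]1O` keeps thiophen-2-yl and carries methyl in place of methylamino on an aromatic carbon next to the ring nitrogen. Among the compounds with values here, the only measured step is an at least 1.3-fold lower number from compound 1 to compound 2 (0.12 log units; that floor lies within the scatter) and it swaps thiophen-2-yl, not methylamino, so it gives no direct size for this change. Within the data shown here, with compound 2 at 75300 nM as the only number, a reading close to that number is expected, with no large step. The expected change is an at least 1.4-fold lower number from compound 1 to compound 3 (0.15 log units; that floor lies within the scatter) and it may not exceed the scatter. The estimate for compound 3 is 70000 nM with an expected range from 20000 nM to 100000 nM in this assay as well.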

Compound 3, half-maximal inhibitory concentration: > 100000 nM
Compound 3: only a limit was reported; the forecaster's own chance of this, stated with the estimate: 50%; middle value at least 1.4-fold (0.15 log units) away from the limit.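

No step can be read from compound 1 to compound 3, because both readings are limits and not numbers: the limit of > 100000 nM in this assay, at which 2 of the 3 values shown sit.

The compounds shown leave open what size of change, if any, methyl in place of methylamino brings on the shared core.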